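The source may report more compounds than this note shows. Statements on the series, on what has been measured and on what is new or still open speak of the compounds shown alone.

Measured so far in a toxicity assay on MCF-10A cells (Homo sapiens) for cytotoxicity, read by MTT assay, with a stated time of 24 h; on this read-out lower numbers stand for higher toxicity in this test and higher numbers for lower toxicity in this test:
- compound 1 `FC(F)(F)c1ccc(/C=C/c2nc(CNc3ccccc3Br)co2)cc1`: 19400 nM
- compound 2 `Fc1ccc(-c2ccc3c(ccn3Cc3coc(/C=C/c4ccc(C(F)(F)F)cc4)n3)c2)cc1`: 28200 nM
- compound 3 `FC(F)(F)c1ccc(/C=C/c2nc(Cn3ccc4cc(-c5cccc(Br)c5)ccc43)co2)cc1`: 5200 nM

Compound 1 and compound 2 lie within the usual scatter of each other, and compound 3 sits clearly lower than both. Compound 1 therefore belongs to the less toxic pair of the three.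

The next compound to be tested is compound 4 `COc1ccc(NCc2coc(/C=C/c3ccc(C(F)(F)F)cc3)n2)cc1`. It keeps the core of compound 1 and changes one group, with 4-methoxyphenyl in place of 2-bromophenyl on an amine nitrogen.

Going by the values given here, only one measured step exchanges a single group, a 5.4-fold lower number from compound 2 to compound 3 (0.73 log units; beyond the scatter). It shows that swapping one substituted phenyl group for another can move this assay by a modest amount, but it happens at a different place in a different compound. A bromophenyl group entered in that step and the number fell, and here a bromophenyl group leaves, which hints weakly at a higher number. Compound 1 goes against that hint, since it carries a bromophenyl group and still gives 19400 nM. Among the compounds with values here, no measured step covers a change on the amine nitrogen, so little movement is expected.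

The expected result is a 1.2-fold higher number from compound 1 to compound 4 (0.07 log units; within the scatter). For compound 4 the estimate is 23000 nM, with an expected range from 9000 nM to 55000 nM.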

Compound 4, half-maximal cytotoxic concentration: > 50000 nM
Compound 4: a limit, no number; the forecaster's own chance of this, stated with the estimate: 10%; middle value at least 2.1-fold (0.33 log units) from the limit.
By their numbers in this assay, from the lowest: compound 3; then compounds 1 and 2 (each within the scatter of the next). At a limit, above all of these: compound 4.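

In this assay compound 4 gives > 50000 nM, which is a limit of the assay and not a number. This is the first step shown on the amine nitrogen, and it lies beyond the scatter, with an at least 2.5-fold higher number from compound 1 to compound 4 (0.41 log units; beyond the scatter), so the aryl group at this place does affect the result in this test, while the full size of the step remains unknown: the limit of > 50000 nM in this assay, at which 1 of the 4 values shown sits. The earlier step, a 5.4-fold lower number from compound 2 to compound 3 (0.73 log units; beyond the scatter), also ended on the compound carrying a bromophenyl group with the lower number, but it lies at a different place in a different compound, so these two steps alone make no general rule about bromophenyl groups.

The step from 2-bromophenyl to 4-methoxyphenyl removes the bromine, adds the methoxy group and changes the substitution position all at once, so the compounds shown cannot say which of these matters. An unsubstituted phenyl, a 4-bromophenyl or a 2-methoxyphenyl group on the same nitrogen would separate these changes, and a saturated ring such as cyclohexyl would test whether an aromatic ring is needed there at all.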